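The compounds below may be only part of what the source reports. "The series", "measured", "known", "first", "only" and "open" are said of these compounds alone.

Of the compounds shown here, three built on one shared core have been tested in a functional assay on FM3A cells (Mus musculus) for antiproliferative activity; a lower number here means a stronger inhibitor, a higher number a weaker inhibitor. Compound 1, `COc1cc(C(=O)c2sc(-c3ccc(C)cc3)cc2N)cc(OC)c1OC`, gives 16 nM. Compound 2, `COc1cc(C(=O)c2sc(-c3cccs3)cc2N)cc(OC)c1OC`, gives 1.7 nM. Compound 3, `COc1cc(C(=O)c2sc(-c3ccc(F)cc3)cc2N)cc(OC)c1OC`, gives 16 nM. Compound 3 thus stands level with compound 1, the two together at the top of the three numbers, while compound 2 sits well below them: a 9.4-fold higher number from compound 2 to compound 3 (0.97 log units; beyond the scatter).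

The next compound, compound 4, is `COc1cc(C(=O)c2sc(-c3ccc(C(F)(F)F)cc3)cc2N)cc(OC)c1OC`. It differs from compound 3 in one place: trifluoromethyl in place of fluoro on an aromatic carbon.

Going by the values given here, only one measured step speaks to a swap of the group on this six-membered ring. That step is no change at the digits printed from compound 1 to compound 3 (within the scatter), which shows that exchanging one small group for another at the same place left the number where it was. The steps of a 9.4-fold lower number from compound 1 to compound 2 (0.97 log units; beyond the scatter) and a 9.4-fold higher number from compound 2 to compound 3 (0.97 log units; beyond the scatter) concern replacing the whole ring and do not bear on this change. Compound 4 is therefore expected to stay close to compound 3, with a 1.3-fold higher number from compound 3 to compound 4 (0.10 log units; within the scatter) estimated as no change beyond the scatter. Compound 4 is estimated at 20 nM, within the range 7 nM to 60 nM.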

Compound 4, half-maximal inhibitory concentration: 540 nM
Compound 4: the middle estimate sits 27-fold (1.43 log units) below what was measured; the whole stated range lies below it.
By their numbers in this assay, from the lowest: compound 2; then compounds 1 and 3 (each within the scatter of the next); then compound 4.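

In this assay, trifluoromethyl in place of fluoro gives a 34-fold higher number from compound 3 to compound 4 (1.53 log units; beyond the scatter) and trifluoromethyl in place of methyl gives a 34-fold higher number from compound 1 to compound 4 (1.53 log units; beyond the scatter) on the same aromatic carbon, para to a large group. Methyl and fluoro had read the same here, so the earlier compounds made this position look indifferent to its small group, yet this change moves the number as far as replacing the whole ring did, and further: thiophen-2-yl and 4-(trifluoromethyl)phenyl now stand apart, with a 320-fold higher number from compound 2 to compound 4 (2.50 log units; beyond the scatter) as the widest gap in the series. No measurement shown here explains why trifluoromethyl behaves so differently from methyl and fluoro.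

Where a chloro, a methoxy or an ethyl group at this place would fall remains open. So does the outcome with an amine or a carboxylic acid there.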